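The compounds below may be only part of what the source reports. "The series", "measured", "known", "first", "only" and "open" are said of these compounds alone.

Compound 1, `CCCCCCCCCCCCCCCCCCNC(=O)[C@H]1CSC(CCCCCCCCCCCC)N1`, gives about 20000 nM in a functional assay on RH7777 cells (Homo sapiens) for antiproliferative activity against RH7777 (Rattus norvegicus), read by sulforhodamine B assay; a higher number here means a weaker inhibitor, a lower number a stronger inhibitor. Compound 2, `CCCCCCCCCCCCCCCCCCNC(=O)[C@H]1CSC(c2c[nH]c3ccccc23)N1`, yields only a limit of the assay in this assay, namely > 20000 nM. The step of a number no lower from compound 1 to compound 2 (the limit leaves the size open) therefore cannot be sized, as the limit of > 20000 nM in this assay, at which 1 of the 2 values shown sits, shows. Compound 3, `CCCCCCCCCCCCCCCCCCNC(=O)[C@H]1CSC(c2ccc(N(C)C)cc2)N1`, differs from compound 2 by 4-(dimethylamino)phenyl in place of 1H-indol-3-yl on a saturated ring carbon. Going by the values given here, the only measured step bearing on this change is the one from compound 1 to compound 2, and it gives no readable size, so no shift beyond the scatter is expected for a step that the limit leaves unreadable from compound 2 to compound 3. Compound 3 is accordingly estimated at 25000 nM, within 8000 nM to 80000 nM, in this assay.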

Compound 3, half-maximal inhibitory concentration: > 20000 nM
Compound 3 was reported as a limit; the forecaster's own chance of this, stated with the estimate: 60%; the middle value is on the limit's open side.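

In this assay, 4-(dimethylamino)phenyl on this saturated ring carbon gives no readable value, just as 1H-indol-3-yl did, and putting it in place of dodecyl gives a number no lower from compound 1 to compound 3 (the limit leaves the size open) while a second aromatic group of a different ring type and with a hydrogen-bond acceptor rather than a donor still yields no number. The steps among compound 1, compound 2 and compound 3 cannot be read, and the comparison stops at one limit: the limit of > 20000 nM in this assay, at which 2 of the 3 values shown sit.

From the compounds shown here alone, how far compound 2 and compound 3 actually lie from each other stays open. So does whether a hexyl chain or a phenyl bearing a carboxylic acid at this place would give a readable value.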